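A Second Methoxy Group and Muscarinic Binding

A few compounds are considered here, and "the series" means these few. Any claim that something is new, unique, unknown or untested is made for them only; others in the source may bear on it.

Compound 1, `COc1ccc(COC(=O)N(c2ccccc2)C2CN3CCC2CC3)cc1F`: 40 nM
Compound 2, `COc1ccc(COC(=O)N(c2ccccc2)C2CN3CCC2CC3)cc1`: 470 nM
Compound 3, `O=C(OCc1ccccc1)N(c1ccccc1)C1CN2CCC1CC2`: 150 nM

In an assay on CHO cells for displacement of a labelled ligand from muscarinic acetylcholine receptor M5 (Homo sapiens), read by scintillation counting, with a stated time of 2 h (on this read-out higher numbers stand for weaker inhibition and lower numbers for stronger inhibition), compound 2 gives the highest number of the three, with compound 3 nearest and compound 1 furthest away. The unmeasured compound 4, `COc1ccc(COC(=O)N(c2ccccc2)C2CN3CCC2CC3)cc1OC`, differs from compound 2 by methoxy in place of hydrogen on an aromatic carbon, the new group sitting ortho to a methoxy group and meta to a large group.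

Going by the values given here, two measured steps bear on this. The step of a 12-fold higher number from compound 1 to compound 2 (1.07 log units; beyond the scatter) shows that a fluoro group at the very same aromatic carbon makes a large difference, and the step of a 3.1-fold lower number from compound 2 to compound 3 (0.50 log units; beyond the scatter) shows that the existing methoxy group itself carries a modest penalty. The remaining step is a 3.8-fold higher number from compound 1 to compound 3 (0.57 log units; beyond the scatter). A methoxy entering where the fluoro sat is therefore expected to lower the number, though less surely than fluoro did, since methoxy is the larger group and the neighbouring methoxy already costs something. Compound 4 is thus estimated at 150 nM, within 40 nM to 600 nM, which would be a modest expected step of a 3.1-fold lower number from compound 2 to compound 4 (0.50 log units; beyond the scatter).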

Compound 4, inhibition constant: 550 nM
Beside the measured number, compound 4's estimate is 3.7-fold (0.56 log units) below it; the range from low to high includes it.
By their numbers in this assay, from the lowest: compound 1; then compound 3; then compounds 2 and 4 (each within the scatter of the next).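

In this assay, methoxy at this aromatic carbon, ortho to a methoxy group, gives a 1.2-fold higher number from compound 2 to compound 4 (0.07 log units; within the scatter), so adding this second methoxy group to compound 2 produces no change that can be told from the scatter. The swap between the two groups at that same carbon is large, a 14-fold higher number from compound 1 to compound 4 (1.14 log units; beyond the scatter), which shows that the low number of compound 1 does not carry over from fluoro to methoxy. No measurement shown here accounts for this difference between fluoro and methoxy.

The compounds shown leave open how other groups at this carbon, such as chloro, hydroxy or an amine, would compare with fluoro and methoxy. They also leave open whether fluoro at this carbon would give a similar step with hydrogen in place of the existing methoxy group.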